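The source may report more compounds than this note shows. Statements on the series, on what has been measured and on what is new or still open speak of the compounds shown alone.

Working notes on the series. Within the data shown here, in a functional assay on the whole organism (strain Wistar) for inhibition, with Rattus norvegicus as the target, read by paw edema, with a stated time of 3 h, at a dose of 10 mg/kg by the intraperitoneal route (on this read-out lower numbers stand for less inhibition and higher numbers for more inhibition at the one dose given (going by the name of the read-out)), compound 1 `O=C(N/N=C/c1ccc(O)cc1)c1cccnc1Nc1cccc(C(F)(F)F)c1` gives 59.5%, the higher of the two numbers measured so far. Among the measured compounds shown here, compound 2 `COc1cc(/C=N/NC(=O)c2cccnc2Nc2cccc(C(F)(F)F)c2)cc(OC)c1OC` gives 28.5% in this assay, a reading well below compound 1 and beyond the usual scatter; no single-point step between these two is recorded, so only the two values themselves can be compared.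

Compound 3 `CN(C)c1ccc(/C=N/NC(=O)c2cccnc2Nc2cccc(C(F)(F)F)c2)cc1` has not yet been measured in this assay. Relative to compound 1 the change is dimethylamino in place of hydroxy on an aromatic carbon. For the measured compounds named here, nothing measured so far isolates this exact change, so the expectation rests on the spread seen between compound 1 and compound 2 on the same ring. Compound 3 is expected to sit somewhat below compound 1, with the step of a number 14.5 percentage points lower from compound 1 to compound 3 (beyond the scatter) estimated as a modest loss, near the edge of the scatter. The estimate for compound 3 in this assay is 45%, with a range from 20% to 70%.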

Compound 3, a percentage reported as inhibition, in the whole organism at one dose (the size of the read-out at that dose, not a potency): 39.5%
Compound 3: middle estimate off by 5.5 percentage points, on the high side, and the stated range covers the measured number.
By their numbers in this assay, from the lowest: compound 2; then compound 3; then compound 1.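

In this assay, among these compounds, the change from hydroxy to dimethylamino on this aromatic carbon, para to a large group, gives the first step that differs in one place: a number 20 percentage points lower from compound 1 to compound 3 (beyond the scatter). The reading at this position therefore depends on the group it carries, with the 4-hydroxyphenyl of compound 1 above the 4-(dimethylamino)phenyl of compound 3 at the one dose given, and the change also takes away a hydrogen-bond donor while adding heavy atoms. Nothing measured here accounts for the drop or separates those two differences.

The compounds shown leave open how a primary amine or a carboxylic acid on the same carbon would read against hydroxy. They also leave open whether this step would hold with a different group elsewhere on the shared core.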